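The source may report more compounds than this note shows. Statements on the series, on what has been measured and on what is new or still open speak of the compounds shown alone.

Measured so far in a functional assay on DU-145 cells (Homo sapiens) for inhibition, read by trypan blue exclusion, with a stated time of 96 h; a higher number here means a weaker inhibitor of growth, a lower number a stronger inhibitor of growth:
compound 1 `O=C(/C(=C\c1cc(Cl)cc(Cl)c1Cl)Sc1ccccc1Br)c1ccc(Cl)cc1` gives 25000 nM
compound 2 `O=C(O)c1ccc(/C=C(/SCc2ccc(Cl)cc2)C(=O)c2ccc(C(=O)O)cc2)cc1` gives > 100000 nM
compound 3 `Cc1ccc(CS/C(=C/c2ccc(O)cc2)C(=O)c2ccc(Cl)cc2)cc1` gives 10000 nM

The value of compound 2 is a limit of the assay and not a number, as the limit of > 100000 nM in this assay, at which 1 of the 3 values shown sits, records. Among the two numbers, compound 1 stands highest; the nearest, compound 3, sits lower by a gap beyond the scatter.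

Compound 4 `O=C(/C(=C\c1c(O)cc(O)cc1O)Sc1ccccc1Br)c1ccc(Cl)cc1` is not yet measured. It differs from compound 1 by 2,4,6-trihydroxyphenyl in place of 2,3,5-trichlorophenyl on a double-bonded chain carbon bound to a double-bonded chain carbon. Among the measured compounds shown here, no measured pair tracks this change; only compound 3, which also carries a hydroxyphenyl group, shows a lower number than compound 1. A small downward step in this assay is expected, near the edge of the scatter. The step of a 1.7-fold lower number from compound 1 to compound 4 (0.22 log units; within the scatter) is the expectation here. Compound 4 is estimated at 15000 nM, with a range from 4000 nM to 60000 nM.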

Compound 4, concentration for 50% growth inhibition: > 100000 nM
Compound 4: only a limit was reported (the forecaster's own chance of this, stated with the estimate: 10%); at least 6.6-fold (0.82 log units) between middle value and limit.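

Among the compounds shown here, this is the first one-place comparison: in this assay, 2,4,6-trihydroxyphenyl in place of 2,3,5-trichlorophenyl on a double-bonded chain carbon bound to a double-bonded chain carbon gives an at least 4.0-fold higher number from compound 1 to compound 4 (0.60 log units; beyond the scatter). The change therefore weakens growth inhibition, something compound 3, which differs from compound 1 in more than one place, could not show. Compound 4 carries a limit of the assay, so the step has a lower bound and no measured size: the limit of > 100000 nM in this assay, at which 2 of the 4 values shown sit.

Which of the hydroxy groups drive the step stays open. So does how methoxy groups or an amine on this ring would read.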